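Methyl at a second ring position in the pyrazoline sulfonamide series

This account rests on a few compounds, and the source may have more. Where it says the series, first, only, none or still open, it means among the compounds named here.

Compound 3 `NS(=O)(=O)c1ccc(N2N=C(c3ccc(Oc4ccccc4)cc3)CC2c2ccccc2)cc1` gives 85000 nM in an ADME assay on Vero 76 cells (Chlorocebus sabaeus) for cytotoxicity, read by MTT assay, with a stated time of 96 h (a lower number here means that less compound is tolerated, a higher number that more compound is tolerated), the second highest of the three numbers measured, with compound 2 `NS(=O)(=O)c1ccc(N2N=C(c3ccc(Oc4ccccc4)cc3)CC2c2ccc(Cl)cc2)cc1` at 88000 nM and compound 1 `Cc1cccc(C2CC(c3ccc(Oc4ccccc4)cc3)=NN2c2ccc(S(N)(=O)=O)cc2)c1` at 81000 nM both within the scatter of it. Compound 4 `Cc1ccccc1C1CC(c2ccc(Oc3ccccc3)cc2)=NN1c1ccc(S(N)(=O)=O)cc1` differs from compound 3 by methyl in place of hydrogen on an aromatic carbon, placed ortho to a large group. The closest comparison is a 1.0-fold higher number from compound 1 to compound 3 (0.02 log units; within the scatter), the same methyl-for-hydrogen exchange read in reverse at another position; a 1.1-fold higher number from compound 1 to compound 2 (0.04 log units; within the scatter) and a 1.0-fold lower number from compound 2 to compound 3 (0.02 log units; within the scatter) likewise stay within the scatter. No step beyond the scatter is therefore expected for this assay. Compound 4 is estimated at 85000 nM, range 55000 nM to 130000 nM, an expected no change at the digits printed from compound 3 to compound 4 (within the scatter).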

Compound 4, half-maximal cytotoxic concentration: 90000 nM
Beside the measured number, compound 4's estimate is 1.1-fold (0.02 log units) below it; measured number inside the range.
By their numbers in this assay, from the lowest: compounds 1, 3, 2 and 4 (each within the scatter of the next).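

In this assay the exchange of phenyl for 2-methylphenyl, with methyl ortho to a large group, gives a 1.1-fold higher number from compound 3 to compound 4 (0.02 log units; within the scatter). The position of the methyl does not separate the compounds, with a 1.1-fold higher number from compound 1 to compound 4 (0.05 log units; within the scatter), and neither does the exchange of 4-chlorophenyl for 2-methylphenyl, with a 1.0-fold higher number from compound 2 to compound 4 (0.01 log units; within the scatter). No supporting data bear on why these steps are so small. Open, going by these compounds, is whether an amine or a carboxylic acid on this aromatic ring would give a step beyond the scatter.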